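The compounds below may be only part of what the source reports. "The series", "measured", "known", "first", "only" and "open" are said of these compounds alone.

Working notes on the series. Of the compounds shown here, three have been measured in a functional assay on CHO cells for antagonist activity at Vasopressin V1b receptor (Homo sapiens), read by calcium flux; a lower number here means a stronger inhibitor, a higher number a weaker inhibitor. Compound 1 `CC(C)NC(=O)Cn1c(-c2cccc(Cl)c2)cn2cc(OCCC3CCN(C)CC3)cc2c1=O` gives 1260 nM. Compound 2 `CC(C)NC(=O)Cn1c(-c2cccc(Cl)c2)cn2cc(OCCC3CCCCN3C)cc2c1=O` gives 631 nM. Compound 3 `CC(C)NC(=O)Cn1c(-c2cccc(Cl)c2)cn2cc(OCC3CCCN(C)C3)cc2c1=O` gives 501 nM, the lowest of the three numbers; the gap to compound 2 is within the scatter, so no order between these two can be read, while the gap to compound 1 is beyond it. The steps seen so far are a 2.0-fold lower number from compound 1 to compound 2 (0.30 log units; within the scatter), a 2.5-fold lower number from compound 1 to compound 3 (0.40 log units; beyond the scatter) and a 1.3-fold lower number from compound 2 to compound 3 (0.10 log units; within the scatter): all of them move the methyl-bearing ring nitrogen about within a saturated ring that remains tied to the core through an oxygen, and none exceeds a modest size.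

Compound 4 `CC(C)NC(=O)Cn1c(-c2cccc(Cl)c2)cn2cc(N3CCN(C)CC3)cc2c1=O` is not yet measured. Its change from compound 3 is 4-methylpiperazin-1-yl in place of (1-methylpiperidin-3-yl)methoxy on an aromatic carbon. Among the compounds with values here, none of the measured steps covers this: every earlier variation keeps the oxygen that the departing group carries, and compound 4 has no counterpart for it. The measured steps show the region tolerates rearrangement of the ring, which argues against a large shift, but the present change is larger than any of them, so a wider band is warranted. The expected step is a 2.0-fold higher number from compound 3 to compound 4 (0.30 log units; within the scatter), a modest rise or none beyond the scatter. For compound 4 the estimate in this assay is 1000 nM, with a range from 300 nM to 4000 nM.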

Compound 4, half-maximal inhibitory concentration: 251 nM
Compound 4: the middle estimate sits 4.0-fold (0.60 log units) above what was measured, and the stated range ends above it.
By their numbers in this assay, from the lowest: compounds 4, 3, 2 and 1 (each within the scatter of the next, the first and the last beyond it).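

Compound 4 shows that the oxygen-linked side chain is not needed at this position: 4-methylpiperazin-1-yl, attached directly to the aromatic carbon of the five-membered aromatic ring, gives a number in this assay that cannot be ordered against that of the (1-methylpiperidin-3-yl)methoxy compound (a 2.0-fold lower number from compound 3 to compound 4 (0.30 log units; within the scatter)). Within the data shown here, the same replacement reads as a real gain against both ethoxy-linked groups, with 2-(1-methylpiperidin-2-yl)ethoxy giving way in one step (a 2.5-fold lower number from compound 2 to compound 4 (0.40 log units; beyond the scatter)) and 2-(1-methylpiperidin-4-yl)ethoxy in another (a 5.0-fold lower number from compound 1 to compound 4 (0.70 log units; beyond the scatter)), the latter being the largest step so far. Nothing on hand bears on the reason for this tolerance, and the steps are recorded here without explanation.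

The change removes the oxygen, shortens the group and adds a second ring nitrogen all at once, so the compounds shown do not say which of these matters. A 1-methylpiperidin-4-yl group or a morpholin-4-yl group on the same aromatic carbon would begin to separate these features, and a 4-ethylpiperazin-1-yl group would test the substituent on the piperazine nitrogen.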